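The source may report more compounds than this note shows. Statements on the series, on what has been measured and on what is new or still open speak of the compounds shown alone.

Three compounds have been measured in a functional assay on HeLa cells (Homo sapiens) for cytotoxicity, read by MTT assay, with a stated time of 24 h; on this read-out higher numbers stand for weaker inhibition and lower numbers for stronger inhibition:

Compound 1 `O=c1nc2ccc(Br)cn2cc1Cc1ccc(Br)cc1`: 931000 nM
Compound 2 `O=c1nc2ccc(Br)cn2cc1Cc1ccc(Cl)cc1`: > 1000000 nM, which is a limit of the assay
Compound 3 `O=c1nc2ccc(Br)cn2cc1Cc1ccccc1`: 152000 nM

Compound 3 has the lowest value of the series. Its nearest neighbour is compound 1, with a 6.1-fold lower number from compound 1 to compound 3 (0.79 log units; beyond the scatter). The value of compound 2 gives only a floor for its step, an at least 6.5-fold lower number from compound 2 to compound 3 (0.81 log units; beyond the scatter).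

Compound 4 `O=c1nc2ccccn2cc1Cc1ccccc1` keeps the unsubstituted benzyl part of compound 3 and changes the shared core: hydrogen in place of bromo on an aromatic carbon. The change is hydrogen in place of bromo on an aromatic carbon, here on the six-membered aromatic ring with 1 nitrogen.

The two steps to compound 3 are the closest guides, as each also puts hydrogen in place of a halogen, although on a different ring. Both are modest and beyond the scatter, and both lower the number. Among the compounds with values here, no measured step removes the bromo from the core, so this guide carries over only loosely. A lowering in this assay smaller than those steps is expected, and it may not clear the scatter. The expected result is a 1.7-fold lower number from compound 3 to compound 4 (0.23 log units; within the scatter). The estimate for compound 4 is 90000 nM, with an expected range from 25000 nM to 350000 nM.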

Compound 4, half-maximal inhibitory concentration: > 1000000 nM
Compound 4 was reported as a limit; the forecaster's own chance of this, stated with the estimate: 10%; middle value at least 11-fold (1.04 log units) away from the limit.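

In this assay, hydrogen in place of bromo on this aromatic carbon of the six-membered aromatic ring with 1 nitrogen gives an at least 6.5-fold higher number from compound 3 to compound 4 (0.81 log units; beyond the scatter), so a bromo at this position goes with the stronger inhibition of this pair. The same kind of change on the benzyl ring runs the other way, with a 6.1-fold lower number from compound 1 to compound 3 (0.79 log units; beyond the scatter), which shows that among these compounds the outcome of removing a bromo depends on the ring that carries it, and that a step on one ring does not predict a step on the other. Compound 4 is reported only as a limit, so its step gives a floor and not a size: the limit of > 1000000 nM in this assay, at which 2 of the 4 values shown sit.

The compounds shown leave open whether this position calls for bromo in particular or would accept another substituent, such as a chloro, a methyl or an amine on the same carbon. They also leave open how far the number would fall with such a group in place, and whether a halogen on the benzyl ring would still raise the number when the core carries one of these other groups.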